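The source may report more compounds than this note shows. Statements on the series, on what has been measured and on what is new or still open speak of the compounds shown alone.

Three compounds have been measured in a functional assay (trachea) with Rattus norvegicus as the target; on this read-out lower numbers stand for lower potency and higher numbers for higher potency (the scale is a negative logarithm):

Compound 1 `CCC(=O)c1ccc2c(c1)C(n1ccccc1=O)=CC(C)(C)O2`: 5.85
Compound 2 `CC1(C)C=C(n2ccccc2=O)c2cc(C(=O)c3cccs3)ccc2O1`: 5.84
Compound 3 `CC1(C)C=C(n2ccccc2=O)c2cc(C(=O)c3ccc(O)cc3)ccc2O1`: 5.87

Compound 3 has the highest of the three numbers, yet the steps of a number 0.02 log units higher from compound 1 to compound 3 (within the scatter) and a number 0.03 log units higher from compound 2 to compound 3 (within the scatter) both lie within the scatter, so the three stand level. Compound 4 `CC1(C)C=C(n2ccccc2=O)c2cc(C=C(C#N)C#N)ccc2O1` differs from compound 3 in one place: 2,2-dicyanoethenyl in place of (4-hydroxyphenyl)carbonyl on an aromatic carbon. The measured steps of a number 0.01 log units lower from compound 1 to compound 2 (within the scatter), a number 0.02 log units higher from compound 1 to compound 3 (within the scatter) and a number 0.03 log units higher from compound 2 to compound 3 (within the scatter) all exchange the group on a carbonyl carbon and all stay within the scatter; none removes the carbonyl itself, so they bear only loosely on this change. On that basis no step beyond the scatter is expected for compound 4, with a wide range: the estimate is 5.8, between 5.2 and 6.4, an expected step of a number 0.07 log units lower from compound 3 to compound 4 (within the scatter).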

Compound 4, logarithm of the reciprocal of the active concentration, log(1/C): 6.3
Compound 4: middle estimate off by 0.50 log units, on the low side; the measured number falls inside the stated range.
By their numbers in this assay, from the lowest: compounds 2, 1 and 3 (each within the scatter of the next); then compound 4.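

In this assay, going by these compounds alone, 2,2-dicyanoethenyl on the aromatic carbon gives a number 0.43 log units higher from compound 3 to compound 4 (beyond the scatter) and a number 0.46 log units higher from compound 2 to compound 4 (beyond the scatter) and a number 0.45 log units higher from compound 1 to compound 4 (beyond the scatter), the first steps beyond the scatter. This position therefore does respond to change, although the three groups on the carbonyl carbon stood level, and here the carbonyl itself is gone. Nothing available explains the rise.

The compounds leave open whether the rise belongs to the two nitriles or to the double bond that carries them. A single nitrile or a carboxylic acid on the same aromatic carbon would bear on that.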